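The compounds below may be only part of what the source reports. "The series", "measured", "known", "first", "only" and "open" are said of these compounds alone.

Compound 1 `COC(=O)c1ccc(C2SCC(=O)N2c2ccc(N3CCN(Cc4cccc([N+](=O)[O-])c4)CC3)cn2)c(OC)c1` and compound 2 `COC(=O)c1ccc(C2SCC(=O)N2c2ccc(N3CCN(S(=O)(=O)c4ccc(OC)cc4)CC3)cn2)c(OC)c1` share one core and differ only at an amine nitrogen in a ring. In a functional assay on Jurkat cells (Homo sapiens) for antiproliferative activity, read by MTT assay and trypan blue exclusion, with a stated time of 72 h (on this read-out lower numbers stand for stronger inhibition and higher numbers for weaker inhibition), compound 1 gives 37400 nM, and in this assay compound 2 gives 45200 nM. The step of a 1.2-fold higher number from compound 1 to compound 2 (0.08 log units; within the scatter) lies within the scatter, so among the two numbers shown compound 2 stands level with compound 1, with nothing to separate them. Compound 3 `COC(=O)c1ccc(C2SCC(=O)N2c2ccc(N3CCN(S(=O)(=O)c4c(C)cc(C)cc4C)CC3)cn2)c(OC)c1` is derived from compound 2 by 2,4,6-trimethylphenyl in place of 4-methoxyphenyl on a sulfonyl sulfur. Within the data shown here, no measured step changes a group on the sulfonyl sulfur; the only step known, a 1.2-fold higher number from compound 1 to compound 2 (0.08 log units; within the scatter), exchanges the whole substituent on the ring nitrogen and is itself within the scatter, so it gives no direction. The step of a 1.1-fold lower number from compound 2 to compound 3 (0.03 log units; within the scatter) is therefore expected to remain within the scatter. Compound 3 is estimated at 42000 nM, with a range from 15000 nM to 120000 nM.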

Compound 3, half-maximal inhibitory concentration: > 100000 nM
Compound 3 gave a limit, no number; the forecaster's own chance of this, stated with the estimate: 20%; at least 2.3-fold (0.37 log units) between middle value and limit.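

In this assay compound 3 gives a limit and not a number: the limit of > 100000 nM in this assay, at which 1 of the 3 values shown sits.

The group on the sulfonyl sulfur does affect this read-out, which the earlier pair could not show: replacing 4-methoxyphenyl with 2,4,6-trimethylphenyl gives an at least 2.2-fold higher number from compound 2 to compound 3 (0.34 log units; beyond the scatter), whereas exchanging the whole substituent on the ring nitrogen gave a 1.2-fold higher number from compound 1 to compound 2 (0.08 log units; within the scatter). The sulfonyl link alone does not set the level, as compound 2 carries it too, and the step against 3-nitrobenzyl on that nitrogen is an at least 2.6-fold higher number from compound 1 to compound 3 (0.42 log units; beyond the scatter).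

The compounds shown leave open whether the change follows the methyl groups or the departure of the methoxy group, and the true size of both new steps remains unknown. Going by these compounds, how a plain phenyl or a 4-methylphenyl on the sulfonyl sulfur would read in this assay also stays open.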